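The source may hold more compounds than are shown below. What is called first, only, known or untested is meant among the compounds shown, and "the series" means these compounds.

In a physicochemical assay for lipophilicity, read by HPLC (a lower number here means a more polar compound, a higher number a more lipophilic compound), compound 1 `O=C1/C(=C/c2ccncc2)C(c2ccccc2)Oc2ccccc21` gives 2.98 and compound 2 `O=C1/C(=C\c2ccncc2)C(c2ccccc2)Oc2ccccc21` gives 2.85. The two differ only in the double bond, drawn E in compound 1 and Z in compound 2. The step is a number 0.13 log units lower from compound 1 to compound 2 (within the scatter), so compound 2 stands level with compound 1 on these numbers. Compound 3 `O=C1/C(=C\c2ccccc2)C(c2ccccc2)Oc2ccccc21` differs from compound 2 in one group: phenyl in place of pyridin-4-yl on a double-bonded chain carbon bound to a double-bonded ring carbon, with phenyl in place of pyridin-4-yl on a double-bonded chain carbon bound to a double-bonded ring carbon. Among the measured compounds shown here, the only measured step, a number 0.13 log units lower from compound 1 to compound 2 (within the scatter), concerns the double bond and not this exchange, so it sets no size for it. Starting from compound 2 at 2.85, a clearly higher number is expected in this assay. The expected step, a number 1.45 log units higher from compound 2 to compound 3 (beyond the scatter), is estimated to lie beyond the scatter. The estimate for compound 3 is 4.3, with an expected range from 3.8 to 4.9.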

Compound 3, partition coefficient: 3.9
The estimate for compound 3 lay 0.40 log units above the measured number, within the range that was stated.
By their numbers in this assay, from the lowest: compounds 2 and 1 (each within the scatter of the next); then compound 3.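

In this assay this position responds strongly to the ring carried on the chain: phenyl in place of pyridin-4-yl gives a number 1.05 log units higher from compound 2 to compound 3 (beyond the scatter) while the earlier pair, which differs only in the double bond, gave no step beyond the scatter. Among the compounds shown here, both groups are six-membered aromatic rings of 6 heavy atoms with no net charge, so this large step goes with replacing the ring nitrogen by carbon, a change the earlier compounds did not touch. Nothing measured here accounts for the size of this step.

From the compounds shown here alone, a single pair also leaves open whether the same exchange would give a comparable step with the double bond drawn E. How an amine, a carboxylic acid or a longer chain on the same carbon would read in this assay also remains open.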